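The source may hold more compounds than are shown below. What is called first, only, known or untested is meant among the compounds shown, and "the series" means these compounds.

Measured so far in an assay for inhibition of inositol hexakisphosphate kinase 2 (Homo sapiens), read by colorimetric assay, coupled enzyme assay and malachite green, with a stated time of 120 min, in the presence of a further agent that is not named here; on this read-out lower numbers stand for stronger inhibition and higher numbers for weaker inhibition:

compound 1 `Cc1cccc(-c2onc3ccc(/C=C/C(=O)O)cc23)c1` — 290 nM
compound 2 `CNC(=O)c1ccc2noc(-c3ccccc3)c2c1` — 2120 nM
compound 3 `O=C(O)c1ccc2noc(-c3ccc(Cc4ccccc4)cc3)c2c1` — 65 nM

Compound 3 holds the lowest number of the three. Its nearest neighbour is compound 1, whose number is higher by a margin beyond the scatter, and compound 2 lies further off still, also beyond the scatter. No two of these compounds differ in only one place, so no single step has been measured yet.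

Compound 4 `O=C(O)c1ccc2noc(-c3ccc(NC(=O)c4ccccc4)cc3)c2c1` is the next compound for this assay. It differs from compound 3 in one place: benzamido in place of benzyl on an aromatic carbon. The change keeps a six-membered aromatic ring of carbon only at the same place on the aromatic carbon, but the benzamido group brings one hydrogen-bond donor and one hydrogen-bond acceptor that the benzyl group lacked.

Among the measured compounds shown here, no measured step of this kind is available to lean on. The expectation is therefore a modest step, more likely toward weaker inhibition than stronger, and possibly within the scatter. Compound 4 is expected to give 120 nM, within a range of 30 nM to 500 nM. That estimate corresponds to an expected step of a 1.8-fold higher number from compound 3 to compound 4 (0.27 log units; within the scatter).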

Compound 4, half-maximal inhibitory concentration: 580 nM
Estimate against measurement, compound 4: 4.8-fold (0.68 log units) below; the measured number lies above the stated range.
By their numbers in this assay, from the lowest: compound 3; then compounds 1 and 4 (each within the scatter of the next); then compound 2.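

In this assay, among the compounds shown here, this aromatic carbon, para to a large group, proves sensitive to what it carries: benzamido in place of benzyl gives an 8.9-fold higher number from compound 3 to compound 4 (0.95 log units; beyond the scatter) as the first single change that can be read. Both groups bring a six-membered aromatic ring of carbon only, so keeping that ring does not by itself hold the number. The step comes with the hydrogen-bond donor and acceptor that benzamido adds, but no data here bear on its cause.

Still open, going by these compounds, is which part of benzamido goes with the step; a plain amine or an ether oxygen as the link joining the two rings would part the amide hydrogen from the carbonyl. On these data alone, whether the step carries over with a tetrazole in place of the carboxylic acid is also open.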